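This account rests on a few compounds, and the source may have more. Where it says the series, first, only, none or still open, it means among the compounds named here.

Working notes on the series. Two compounds carry numbers in a functional assay on HT-29 cells (Homo sapiens) for antiproliferative activity, read by sulforhodamine B assay, with a stated time of 72 h; on this read-out higher numbers stand for weaker inhibition and lower numbers for stronger inhibition. Compound 1 `Cc1ccccc1NC(=S)N/N=C/c1ccc2ccccc2n1` gives 42300 nM in this assay. Compound 2 `Cc1csc2sc(/C=N/NC(N)=S)c(C)c12` gives 57500 nM in this assay. Within the data shown here, the two numbers lie within the scatter of each other, so compound 1 cannot be set apart from compound 2 on this assay; both sit in the weak range, and no step between measured compounds is available.

Compound 3 `S=C(NCc1ccccc1)N/N=C/c1ccc2ccccc2n1` is the next point. It differs from compound 1 in one place: benzyl in place of 2-methylphenyl on an amide-type nitrogen. Among the measured compounds shown here, no measured pair informs this change, so the expected step from compound 1 to compound 3, a 1.1-fold lower number from compound 1 to compound 3 (0.02 log units; within the scatter), is set at no change beyond the scatter, in either direction, as an estimate only.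

On that basis compound 3 is estimated to give 40000 nM in this assay, with a range from 15000 nM to 120000 nM.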

Compound 3, half-maximal inhibitory concentration: 75700 nM
For compound 3 the middle estimate is 1.9-fold (0.28 log units) below the measured one, within the range that was stated.
By their numbers in this assay, from the lowest: compounds 1, 2 and 3 (each within the scatter of the next).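

At the amide-type nitrogen next to the thiocarbonyl carbon, the series now has its first one-place step: in this assay, benzyl in place of 2-methylphenyl gives a 1.8-fold higher number from compound 1 to compound 3 (0.25 log units; within the scatter), which lies within the scatter. The two groups have the same heavy-atom count and each has one six-membered aromatic ring, and on this read-out the exchange cannot be told from no change, so it gives no sign that this position responds to the swap. No measurement at hand bears on the reason for the size of this step.

On these data alone, whether a longer chain such as phenethyl, or an amine such as morpholine, on this nitrogen would move the number beyond the scatter remains open. Also open, as far as these compounds go, is whether the same exchange would read the same way on another core, such as that of compound 2.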